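The compounds below may be only part of what the source reports. "The series", "measured", "known", "first", "only" and "open" are said of these compounds alone.

Compound 2 `O=C(Nc1ccc(Cl)cc1)c1c(O)c2cccnc2n(-c2ccccc2)c1=O` stands lowest of the two compounds measured in a functional assay on the whole organism for inhibition, with Rattus norvegicus as the target, read by cytopathic effect and paw edema, at a dose of 100 mg/kg by the oral route (a higher number here means more inhibition at the dose given (going by the name of the read-out), a lower number less inhibition), where compound 2 gives 2.5%. Compound 1 `O=C(Nc1ccccn1)c1c(O)c2cccnc2n(-c2ccccc2)c1=O` gives 14.6%, and the step of a number 12.1 percentage points lower from compound 1 to compound 2 (beyond the scatter) came with 4-chlorophenyl in place of pyridin-2-yl on an amide-type nitrogen. Compound 3 `O=C(Nc1ccc([N+](=O)[O-])cc1)c1c(O)c2cccnc2n(-c2ccccc2)c1=O` differs from compound 2 by nitro in place of chloro on an aromatic carbon. Within the data shown here, no measured step exchanges a group on that ring, so the single known step only shows that changing the group on the amide-type nitrogen can shift the read-out modestly. The expected step of a number 5.5 percentage points higher from compound 2 to compound 3 (within the scatter) is therefore small, within the scatter. Compound 3 is estimated at 8%, between 0% and 25%.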

Compound 3, a percentage reported as inhibition, in the whole organism at one dose (the size of the read-out at that dose, not a potency): -25.8%
Compound 3: the middle estimate sits 33.8 percentage points above what was measured, and the stated range ends above it.
By their numbers in this assay, from the lowest: compound 3; then compound 2; then compound 1.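

The earlier pair showed only an exchange of the whole group on the amide-type nitrogen. Here one swap on the aromatic ring, chloro to nitro, changes the result in this assay on its own, giving a number 28.3 percentage points lower from compound 2 to compound 3 (beyond the scatter) at this place. With the 4-nitrophenyl group in place of pyridin-2-yl, the change is a number 40.4 percentage points lower from compound 1 to compound 3 (beyond the scatter) and is larger still. Nothing measured here explains either step. On these data alone, whether an amine or a methoxy group at this place would behave like chloro or like nitro remains open.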